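Switching an ethoxyphenyl for an ethenyl ester at the far end

The source may report more compounds than this note shows. Statements on the series, on what has been measured and on what is new or still open speak of the compounds shown alone.

Measured compounds:
- Compound 1 `COC(=O)/C=C/c1cccc(N(Cc2ccc(/C=C/c3cccc(F)c3)cc2)C(=O)C(C)C)c1` gives 71 nM in an assay on isolated protein with Bile acid receptor (Homo sapiens) as the target; a lower number here means that less compound is needed, a higher number that more compound is needed for the effect
- Compound 2 `CCOc1cccc(-c2ccc(CN(C(=O)C3CCCCC3)c3cccc(/C=C/C(=O)OC)c3)cc2)c1` gives 147 nM in this assay
- Compound 3 `CCOc1cccc(-c2ccc(CN(C(=O)C(C)C)c3cccc(/C=C/C(=O)OC)c3)cc2)c1` gives 173 nM in this assay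

Among these three, compound 2 stands second highest: its nearest neighbour is compound 3, within the scatter, while compound 1 sits lower by a step beyond the scatter. The measured steps are a 1.2-fold higher number from compound 2 to compound 3 (0.07 log units; within the scatter) and a 2.4-fold higher number from compound 1 to compound 3 (0.39 log units; beyond the scatter).

Compound 4 `CCOC(=O)/C=C/c1ccc(CN(C(=O)C2CCCCC2)c2cccc(/C=C/C(=O)OC)c2)cc1` differs from compound 2 in one place: 2-(ethoxycarbonyl)ethenyl in place of 3-ethoxyphenyl on an aromatic carbon. Among the measured compounds shown here, no measured step exchanges exactly these two groups. The closest guide is the step from compound 1 to compound 3, where 3-ethoxyphenyl replaced another ethenyl-linked group and the number rose modestly. Here the 3-ethoxyphenyl leaves again in favour of an ethenyl-linked group, but one without a ring. Because a 2.4-fold higher number from compound 1 to compound 3 (0.39 log units; beyond the scatter) was modest, the change is expected to be modest too, with little confidence in its direction. Compound 4 is therefore estimated at 180 nM, with a range of 60 nM to 600 nM, which means an expected step of a 1.2-fold higher number from compound 2 to compound 4 (0.09 log units; within the scatter).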

Compound 4, half-maximal effective concentration: > 1000 nM
Compound 4: only a limit was reported (the forecaster's own chance of this, stated with the estimate: 10%); middle value at least 5.5-fold (0.74 log units) from the limit.
By their numbers in this assay, from the lowest: compound 1; then compounds 2 and 3 (each within the scatter of the next). At a limit, above all of these: compound 4.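

Earlier changes, at this position and on the carbonyl, moved the number only modestly, so this position could have seemed tolerant. Replacing 3-ethoxyphenyl with 2-(ethoxycarbonyl)ethenyl on this aromatic carbon instead gives an at least 6.8-fold higher number from compound 2 to compound 4 (0.83 log units; beyond the scatter) in this assay, the largest step among the compounds shown, so what sits here can matter a great deal. For compound 4 only a limit was reported: the limit of > 1000 nM in this assay, at which 1 of the 4 values shown sits.

This single change removes a six-membered aromatic ring and brings in an ester with two double bonds outside aromatic rings, so the compounds shown cannot tell which of these differences matters. A plain phenyl group, or a carboxylic acid in place of the ethyl ester on the ethenyl chain, would help to separate them.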